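A few compounds are considered here, and "the series" means these few. Any claim that something is new, unique, unknown or untested is made for them only; others in the source may bear on it.

Among the compounds with values here, in a functional assay on HeLa cells (Homo sapiens) for antiproliferative activity, read by MTT assay, with a stated time of 48 h (a higher number here means a weaker inhibitor, a lower number a stronger inhibitor), compound 2 (`COc1ccc(C(=O)c2ccc(OC)c3c2OC(C)(C)C=C3)c(NC(=O)CO)c1`) gives 100 nM, the lowest of the three numbers so far. Compound 3 (`COc1ccc(C(=O)c2ccc(OC)c3c2C=CC(C)(C)O3)c(NC(=O)CO)c1`) gives 310 nM, and compound 1 (`COc1ccc(C(=O)c2ccc(OC)c3c2OC(C)(C)C=C3)c(NC(=O)CBr)c1`) gives 2140 nM.

The next entry is compound 4 (`COc1ccc(C(=O)c2ccc(OC)c3c2OC(C)(C)C=C3)c(NC(=O)CN)c1`), which carries amino in place of hydroxy on a saturated chain carbon bound to a carbonyl carbon.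

Within the data shown here, one measured step bears on this place: a 21-fold lower number from compound 1 to compound 2 (1.33 log units; beyond the scatter), with hydroxy in place of bromo. This large step shows that the group on this carbon can move the number well beyond the scatter in this assay. Among the measured compounds shown here, it gives no direction for amino, however, and the series holds no other example of that group. A much smaller step is expected here, probably towards a higher number, since compound 2 already stands lowest. The estimated step is a 1.8-fold higher number from compound 2 to compound 4 (0.26 log units; within the scatter). For compound 4 the expected value is 180 nM, with an estimated range of 50 nM to 700 nM.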

Compound 4, half-maximal inhibitory concentration: 410 nM
Compound 4: the middle estimate sits 2.3-fold (0.36 log units) below what was measured, and the stated range covers the measured number.
By their numbers in this assay, from the lowest: compound 2; then compounds 3 and 4 (each within the scatter of the next); then compound 1.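

In this assay, the group on this saturated chain carbon bound to a carbonyl carbon now has a third reading, and a 4.1-fold higher number from compound 2 to compound 4 (0.61 log units; beyond the scatter) separates amino from hydroxy, although the computed counts of heavy atoms, hydrogen-bond donors and acceptors and net charge are the same for both groups. Amino keeps part of the gain over bromo, with a 5.2-fold lower number from compound 1 to compound 4 (0.72 log units; beyond the scatter), so the three groups at this place on the shared core run hydroxy, amino, bromo from the lowest number, each step beyond the scatter. Nothing measured here gives a reason for this order.

As far as these compounds go, it remains open whether a dimethylamino group, or a longer chain carrying hydroxy or amino, would stand nearer to hydroxy or to bromo on this carbon. It also remains open how amino behaves on the core of compound 3, where only hydroxy is shown.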